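The source may hold more compounds than are shown below. What is called first, only, known or untested is meant among the compounds shown, and "the series" means these compounds.

Measured compounds:
compound 1 `Cc1ncc2cc(-c3c(Cl)cccc3Cl)c(N)nc2n1` with 30
compound 2 `CC(=O)Nc1nc2nc(C)ncc2cc1-c1c(Cl)cccc1Cl` with 4.1
compound 3 `COC(=O)Nc1nc2nc(C)ncc2cc1-c1c(Cl)cccc1Cl` with 4.2

In a physicochemical assay for acid dissociation, compound 2 stands lowest of the three values. Compound 3 lies closest, a number 0.10 log units higher from compound 2 to compound 3 (within the scatter), while compound 1 is far away, a number 25.90 log units lower from compound 1 to compound 2 (beyond the scatter). The unmeasured compound 4 `CC(=O)N(C)c1nc2nc(C)ncc2cc1-c1c(Cl)cccc1Cl` differs from compound 2 by methyl in place of hydrogen on an amide-type nitrogen. Among the compounds with values here, no measured step carries this exact change. The two steps that bear on it only loosely are a number 25.90 log units lower from compound 1 to compound 2 (beyond the scatter) and a number 25.80 log units lower from compound 1 to compound 3 (beyond the scatter), which show that placing an acyl group on the ring nitrogen brings the value down sharply, and a number 0.10 log units higher from compound 2 to compound 3 (within the scatter), which shows that swapping methyl for methoxy on the carbonyl carbon leaves the value essentially unchanged. Since compound 4 keeps the acetyl group and only adds a methyl on the amide-type nitrogen, the value is expected to stay near that of compound 2, with a step of a number 0.20 log units higher from compound 2 to compound 4 (within the scatter) likely within the scatter. Compound 4 is therefore estimated at 4.3, within a range from 3.5 to 5.2.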

Compound 4, acid dissociation constant: 4.2
Estimate against measurement, compound 4: 0.10 log units above; measured number inside the range.
By their numbers in this assay, from the lowest: compounds 2, 3 and 4 (each within the scatter of the next); then compound 1.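

In this assay, compound 4 is the first compound here in which the amide hydrogen is replaced while the acetyl group stays, and the step is small: a number 0.10 log units higher from compound 2 to compound 4 (within the scatter), so among these compounds the value does not depend on that hydrogen. Compound 4 also sits with the methoxycarbonyl compound, no change at the digits printed from compound 3 to compound 4 (within the scatter), and the large gap to the free amino compound remains with the methyl in place: a number 25.80 log units lower from compound 1 to compound 4 (beyond the scatter). Nothing measured here accounts for this result.

As far as these compounds go, whether a longer chain such as propyl, or a chain ending in an amine, on this nitrogen would also leave the value in place stays open. So does whether a methyl on the nitrogen of compound 3 would behave as it does on compound 2.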